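Amine nitrogen substituents and growth inhibition: toward compound 4

The source may hold more compounds than are shown below. What is called first, only, known or untested is meant among the compounds shown, and "the series" means these compounds.

Compound 1 `O=C(NO)c1cnc(N2C[C@@H]3[C@H](C2)[C@H]3NC(=O)c2cccs2)nc1` at 3600 nM
Compound 2 `O=C(NO)c1cnc(N2C[C@@H]3[C@H](C2)[C@H]3NCC2CCCCC2)nc1` at 160 nM
Compound 3 `O=C(NO)c1cnc(N2C[C@@H]3[C@H](C2)[C@H]3NCc2ccc(F)cc2)nc1` at 380 nM

All three values come from a functional assay on HCT-116 cells (Homo sapiens) for antiproliferative activity, read by WST assay, with a stated time of 72 h (on this read-out higher numbers stand for weaker inhibition of growth and lower numbers for stronger inhibition of growth), and compound 1 has the highest number of the set, with both steps away from it beyond the scatter. Compound 4 `O=C(NO)c1cnc(N2C[C@@H]3[C@H](C2)[C@H]3NCc2ccc(Br)cc2)nc1` is not yet measured. Its difference from compound 1 is 4-bromobenzyl in place of (thiophen-2-yl)carbonyl on an amine nitrogen with 4-bromobenzyl in place of (thiophen-2-yl)carbonyl on an amine nitrogen.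

Among the compounds with values here, the closest precedent is a 9.5-fold lower number from compound 1 to compound 3 (0.98 log units; beyond the scatter) for the 4-fluorobenzyl change. The cyclohexylmethyl change gives a 23-fold lower number from compound 1 to compound 2 (1.35 log units; beyond the scatter) in the same direction. The remaining comparison, a 2.4-fold higher number from compound 2 to compound 3 (0.38 log units; beyond the scatter) shows that the two replacements differ only modestly. Within the data shown here, no measured pair compares bromine with fluorine on the benzyl group, so the range stays wide.

A modest to large drop in this assay is therefore expected, and the expected step is an 11-fold lower number from compound 1 to compound 4 (1.05 log units; beyond the scatter) beyond the scatter. Compound 4 is estimated at 320 nM with an expected range of 120 nM to 800 nM on this read-out.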

Compound 4, concentration for 50% growth inhibition: 250 nM
For compound 4 the middle estimate is 1.3-fold (0.11 log units) above the measured one; low and high end bracket the measured number.
By their numbers in this assay, from the lowest: compounds 2, 4 and 3 (each within the scatter of the next, the first and the last beyond it); then compound 1.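

In this assay the replacement of (thiophen-2-yl)carbonyl on the amine nitrogen now holds for a third group, with 4-bromobenzyl giving a 14-fold lower number from compound 1 to compound 4 (1.16 log units; beyond the scatter). Bromo in place of fluoro on the aromatic carbon gives a 1.5-fold lower number from compound 3 to compound 4 (0.18 log units; within the scatter), and 4-bromophenyl in place of cyclohexyl gives a 1.6-fold higher number from compound 2 to compound 4 (0.19 log units; within the scatter), so compound 4 cannot be separated from either neighbour, although compounds 2 and 3 remain apart (a 2.4-fold higher number from compound 2 to compound 3 (0.38 log units; beyond the scatter)). Nothing available on these compounds accounts for these values.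

The compounds shown leave open how a hydroxyl, an amine or a carboxylic acid in place of the halogen on the benzyl group would read in this assay. They also leave open whether a longer chain between the amine nitrogen and the ring keeps the lower numbers.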